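The compounds below may be only part of what the source reports. "The series", "measured", "known", "first", "only" and "open" are said of these compounds alone.

Working notes on the series. Compound 1 `CC(O)(CSc1ccc(F)cc1)C(=O)Nc1ccc(S(F)(F)(F)(F)F)cc1` and compound 2 `CC(O)(CSc1ccc(C(F)(F)F)cc1)C(=O)Nc1ccc(S(F)(F)(F)(F)F)cc1` share one core and differ by trifluoromethyl in place of fluoro on an aromatic carbon. In a functional assay on DU-145 cells (Homo sapiens) for antiproliferative activity, read by propidium iodide staining, with a stated time of 96 h (a higher number here means a weaker inhibitor, a lower number a stronger inhibitor), compound 1 gives 25400 nM, and compound 2 gives 28800 nM, a step of a 1.1-fold higher number from compound 1 to compound 2 (0.05 log units; within the scatter). Compound 3 `CC(O)(CS(=O)(=O)c1ccc(F)cc1)C(=O)Nc1ccc(S(F)(F)(F)(F)F)cc1` carries a second core; the difference between the core of compound 1 and the core of compound 3 is not broken down here. In this assay compound 3 gives 27700 nM, which sits within the scatter of both compound 1 and compound 2. Compound 4 `CC(O)(CS(=O)(=O)c1ccc(C(F)(F)F)cc1)C(=O)Nc1ccc(S(F)(F)(F)(F)F)cc1` is not yet measured and differs from compound 3 by trifluoromethyl in place of fluoro on an aromatic carbon, the same kind of change as from compound 1 to compound 2, at a place described in the same words. Within the pair of compound 1 and compound 2 this change moved the number only by a 1.1-fold higher number from compound 1 to compound 2 (0.05 log units; within the scatter), so the step is expected to be a 1.1-fold higher number from compound 3 to compound 4 (0.03 log units; within the scatter). Compound 4 is therefore estimated at 30000 nM, with a plausible range of 15000 nM to 60000 nM.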

Compound 4, half-maximal inhibitory concentration: 29300 nM
Beside the measured number, compound 4's estimate is 1.0-fold (0.01 log units) above it, within the range that was stated.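

In this assay, trifluoromethyl in place of fluoro on the second core gives a 1.1-fold higher number from compound 3 to compound 4 (0.02 log units; within the scatter). Set beside the step on the first core, the two do not differ: the same change on two cores in this assay, a 1.1-fold higher number (0.05 log units; within the scatter) from compound 1 to compound 2 and a 1.1-fold higher number (0.02 log units; within the scatter) from compound 3 to compound 4, 1.1-fold (0.03 log units) apart, within the scatter of two such steps. The change therefore carries across these two cores as a step within the scatter each time, but this is agreement between two steps too small to read; it does not show that a larger effect of the change would carry over, or that the same would hold on any other core.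

The compounds shown leave open whether any other group on this aromatic carbon, such as an amine or a carboxylic acid, would move the number beyond the scatter.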